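The compounds below may be only part of what the source reports. "The series", "measured", "known", "first", "only" and "open" are said of these compounds alone.

Working notes on the series.

Compound 3 `CC[C@H](C)[C@@H]1C(=O)N[C@H](C2Cc3ccccc3C2)C(=O)N1[C@@H](C(=O)NC)c1cnc(C)cc1C` and compound 1 `CC[C@H](C)[C@@H]1C(=O)N[C@H](C2Cc3ccccc3C2)C(=O)N1[C@@H](C(=O)N1CCOCC1)c1cnc(C)cc1C` share one core and differ only at the amide: morpholin-4-yl in place of methylamino on a carbonyl carbon. In an ADME assay on the whole organism (plasma) for pharmacokinetics, with Rattus norvegicus as the target, at a dose of 5 mg/kg by the oral route (on this read-out higher numbers stand for higher exposure at the dose given and lower numbers for lower exposure), compound 3 gives 407 ng.h/mL, and compound 1 gives 1110 ng.h/mL. The step is a 2.7-fold higher number from compound 3 to compound 1 (0.44 log units; beyond the scatter), so the morpholine amide carries the higher exposure within this pair.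

Compound 2 `CCC(CC)[C@@H]1C(=O)N[C@H](C2Cc3ccccc3C2)C(=O)N1[C@@H](C(=O)NC)c1ccc(C)nc1C` sits on a second core; the difference between the two cores is not broken down here. In this assay compound 2 gives 1250 ng.h/mL. The values of compound 1 and compound 2 are within the scatter of each other and are not ordered. Compound 2 and compound 3 are not connected by a single counted difference, and only their two values can be set side by side.

Compound 4 `CCC(CC)[C@@H]1C(=O)N[C@H](C2Cc3ccccc3C2)C(=O)N1[C@@H](C(=O)N1CCOCC1)c1ccc(C)nc1C` is the methylamino-to-morpholine partner of compound 2 on the second core: morpholin-4-yl in place of methylamino on a carbonyl carbon. The change is the same one made from compound 3 to compound 1, at the same place, a carbonyl carbon whose other neighbour is a saturated chain carbon. It occurs twice among these four compounds and has been measured once.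

The expectation for compound 4 rests on that single measured step, because a 2.7-fold higher number from compound 3 to compound 1 (0.44 log units; beyond the scatter) was seen on the first core. The estimated step is a 2.4-fold higher number from compound 2 to compound 4 (0.38 log units; beyond the scatter), held a little short of the measured one since the core is not the same. In this assay compound 4 is expected to give 3000 ng.h/mL, with an expected range from 1300 ng.h/mL to 7000 ng.h/mL.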

Compound 4, area under the concentration-time curve: 2330 ng.h/mL
Compound 4: the middle estimate sits 1.3-fold (0.11 log units) above what was measured, within the range that was stated.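

On the second core, the change from methylamino to morpholin-4-yl on a carbonyl carbon gives a 1.9-fold higher number from compound 2 to compound 4 (0.27 log units; within the scatter) in this assay, so compound 2 and compound 4 are not ordered on this read-out taken by itself. Set beside the step on the first core, the new step does not differ from it: the same change on two cores in this assay, a 2.7-fold higher number (0.44 log units; beyond the scatter) from compound 3 to compound 1 and a 1.9-fold higher number (0.27 log units; within the scatter) from compound 2 to compound 4, 1.5-fold (0.17 log units) apart, within the scatter of two such steps. This shows that the two cores return steps of a size that cannot be told apart and that nothing here separates the effect of the change on one core from its effect on the other, but it does not show an established gain in exposure on the second core alone, and two pairs are too few to fix the size of the step or to support a rule for any further core in the series.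

The compounds shown leave open whether other groups on the same carbonyl carbon, such as piperidin-1-yl, dimethylamino or a longer chain on the amide nitrogen, would give a step like that of morpholin-4-yl. Within the data shown here, they also leave open how much of the spread in the values comes from the difference between the two cores, which no single counted step here isolates.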